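Working notes: methoxy in place of trifluoromethyl

A few compounds are considered here, and "the series" means these few. Any claim that something is new, unique, unknown or untested is made for them only; others in the source may bear on it.

Values in a functional assay on B16-F10 cells (Mus musculus) for antiproliferative activity, read by MTT assay, with a stated time of 48 h; a higher number here means a weaker inhibitor, a lower number a stronger inhibitor:
compound 1 `CCCC(C)Oc1ccc(C(=O)/C=C/c2c(/C=C/c3ccc(OC)cc3)cc(OC)cc2OC)cc1` gives 6.7 ug/mL
compound 2 `COc1ccc(/C=C/c2cc(OC)cc(OC)c2/C=C/C(=O)c2ccc(C(F)(F)F)cc2)cc1` gives 4.3 ug/mL
compound 3 `COc1ccc(/C=C/c2cc(OC)cc(OC)c2/C=C/C(=O)c2ccccc2)cc1` gives 3.7 ug/mL

Compound 2 at 4.3 ug/mL stands within the scatter of the other two compounds. The next compound is compound 4 `COc1ccc(/C=C/c2cc(OC)cc(OC)c2/C=C/C(=O)c2ccc(OC)cc2)cc1` with methoxy in place of trifluoromethyl on an aromatic carbon as the change, methoxy in place of trifluoromethyl on an aromatic carbon, para to a large group. Going by the values given here, three measured steps bear on it at that place: a 1.6-fold lower number from compound 1 to compound 2 (0.19 log units; within the scatter) and a 1.2-fold lower number from compound 2 to compound 3 (0.07 log units; within the scatter) and a 1.8-fold lower number from compound 1 to compound 3 (0.26 log units; within the scatter) all stay within the scatter. Among the compounds with values here, no measured compound carries methoxy there. In this assay no step beyond the scatter is therefore expected, and no direction can be given. The estimated step is a 1.1-fold higher number from compound 2 to compound 4 (0.05 log units; within the scatter) and it is expected to stay within the scatter. Compound 4 is estimated at 4.8 ug/mL with an expected range from 2.8 ug/mL to 8 ug/mL in this series.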

Compound 4, half-maximal inhibitory concentration: 5.8 ug/mL
Compound 4: the middle estimate sits 1.2-fold (0.08 log units) below what was measured; measured number inside the range.
By their numbers in this assay, from the lowest: compounds 3, 2, 4 and 1 (each within the scatter of the next).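

In this assay, methoxy on this aromatic carbon, para to a large group, gives a 1.3-fold higher number from compound 2 to compound 4 (0.13 log units; within the scatter) against trifluoromethyl, a 1.6-fold higher number from compound 3 to compound 4 (0.20 log units; within the scatter) against hydrogen and a 1.2-fold lower number from compound 1 to compound 4 (0.06 log units; within the scatter) against the 1-methylbutyl ether, so an oxygen-linked group with only methyl on the oxygen also fails to separate from the others. All four groups at this place now lie within the scatter of one another, which gives no order among them. Nothing available accounts for these small steps.

Open, from the compounds shown here alone, is whether an amine or a carboxylic acid here would give a step beyond the scatter.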